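The source may report more compounds than this note shows. Statements on the series, on what has been measured and on what is new or still open speak of the compounds shown alone.

Series notes. Compound 1 `Cc1ccc(CS(=O)(=O)/C(=C/c2c(O)cc(O)cc2O)C(=O)c2ccc(Cl)cc2)cc1`, compound 2 `Cc1ccc(C)c(/C=C(\C(=O)c2ccc(Cl)cc2)S(=O)(=O)c2ccc(Br)cc2)c1` and compound 3 `COc1ccc(/C=C(\C(=O)c2ccc(Cl)cc2)S(=O)(=O)c2ccc(Br)cc2)cc1O` share one core and differ in the aryl on a double-bonded chain carbon bound to a double-bonded chain carbon, compound 1 differing elsewhere as well. In a functional assay on DU-145 cells (Homo sapiens) for inhibition, read by trypan blue exclusion, with a stated time of 96 h (on this read-out higher numbers stand for weaker inhibition of growth and lower numbers for stronger inhibition of growth), compound 1 gives only a limit, > 100000 nM. Compound 2 gives 1000 nM, and compound 3 gives 10000 nM, the highest of the two numbers, separated by the step of a 10-fold higher number from compound 2 to compound 3 (1.00 log units; beyond the scatter). Compound 4 `O=C(/C(=C\c1c(O)cc(O)cc1O)S(=O)(=O)c1ccc(Br)cc1)c1ccc(Cl)cc1` carries 2,4,6-trihydroxyphenyl in place of 3-hydroxy-4-methoxyphenyl on a double-bonded chain carbon bound to a double-bonded chain carbon. For the measured compounds named here, the one measured step at that place is a 10-fold higher number from compound 2 to compound 3 (1.00 log units; beyond the scatter). The 2,4,6-trihydroxyphenyl of compound 4 also sits in compound 1, which gives a limit (the limit of > 100000 nM in this assay, at which 1 of the 3 values shown sits). A further rise beyond the scatter is therefore expected, a 4.0-fold higher number from compound 3 to compound 4 (0.60 log units; beyond the scatter), with a fair chance of a limit. Compound 4 is estimated at 40000 nM, between 8000 nM and 200000 nM.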

Compound 4, concentration for 50% growth inhibition: > 100000 nM
Compound 4: no number, only a limit (the forecaster's own chance of this, stated with the estimate: 35%); middle value at least 2.5-fold (0.39 log units) from the limit.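

In this assay the 2,4,6-trihydroxyphenyl also gives a limit with 4-bromophenyl on the sulfonyl sulfur, so that limit no longer belongs to compound 1 alone: the limit of > 100000 nM in this assay, at which 2 of the 4 values shown sit.

The change at this place now gives an at least 10-fold higher number from compound 3 to compound 4 (1.00 log units; beyond the scatter) and an at least 100-fold higher number from compound 2 to compound 4 (2.00 log units; beyond the scatter), both sizes being bounds set by the limit of compound 4. The step between compound 1 and compound 4 cannot be read, as both are limits.

Still open, going by these compounds, is whether the loss follows the number of hydroxyl groups or their arrangement on the ring. On these data alone, how an aminophenyl or a carboxyphenyl would read at this place also remains open.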